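This account rests on a few compounds, and the source may have more. Where it says the series, first, only, none or still open, it means among the compounds named here.

Compound 1, `CN(C(=S)SCc1ccc(C(=O)Nc2ccccc2N)cc1)c1cccnc1`, and compound 2, `Nc1ccccc1NC(=O)c1ccc(CSC(=S)N2CCN(Cc3ccncc3)CC2)cc1`, share one core and differ only in the group bonded to the thiocarbonyl carbon. Among the compounds with values here, in a functional assay on HeLa cells (Homo sapiens) for antiproliferative activity, read by CCK-8 assay, with a stated time of 72 h, tested at 2 uM (on this read-out higher numbers stand for a stronger effect at the one concentration tested and lower numbers for a weaker effect), compound 1 gives 16%, the lower of the two numbers known here, while compound 2 gives 59.5%, a gap that lies beyond the usual scatter of this kind of measurement. Compound 3, `CC1CCN(C(=S)SCc2ccc(C(=O)Nc3ccccc3N)cc2)CC1`, has not yet been measured. It differs from compound 1 in a single place: 4-methylpiperidin-1-yl in place of methyl(pyridin-3-yl)amino on a thiocarbonyl carbon. Within the data shown here, no measured pair shows this exact exchange, so the expectation rests only on the two numbers above. A modest rise is expected, since compound 2 reaches 59.5% with a different ring-bearing group on the same thiocarbonyl carbon. For compound 3 the expected step is a number 14 percentage points higher from compound 1 to compound 3 (beyond the scatter), upward but well short of the gap to compound 2. The estimate for compound 3 in this assay is 30%, with a range from 10% to 55%.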

Compound 3, a percentage reported as inhibition, at one concentration (the size of the read-out at that concentration, not a potency): 46.8%
The estimate for compound 3 lay 16.8 percentage points below the measured number, within the range that was stated.
By their numbers in this assay, from the lowest: compound 1; then compound 3; then compound 2.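

In this assay, putting 4-methylpiperidin-1-yl in place of methyl(pyridin-3-yl)amino on a thiocarbonyl carbon gives a number 30.8 percentage points higher from compound 1 to compound 3 (beyond the scatter), so this one exchange is enough to change the read-out strongly. The entering group has a six-membered non-aromatic ring rather than a six-membered aromatic ring, and it lifts the number without the further ring carried by compound 2, although compound 3 at 46.8% still stays under compound 2 at 59.5%. No measurement shown here explains the step.

The exchange alters the whole group at once. The part of it that matters cannot be singled out. Going by these compounds, whether a morpholine ring, a plain piperidine ring without its methyl, or a small dimethylamino group at this carbon would give a similar number remains open.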